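Replacing the 4-hydroxybut-1-yn-1-yl chain with a selenium group

The source may report more compounds than this note shows. Statements on the series, on what has been measured and on what is new or still open speak of the compounds shown alone.

In a functional assay on SK-MEL-147 cells (Homo sapiens) for cytotoxicity, read by MTT assay, with a stated time of 24 h (a lower number here means that less compound is needed, a higher number that more compound is needed for the effect), compound 1 (`CCOC(=O)c1cc([Se]c2ccccc2)c2cc(OC)ccc2n1`) gives 33000 nM. Compound 2 (`CCOC(=O)c1cc([Se]c2ccc(OC)cc2)c2cc(OC)ccc2n1`) reads >= 54300 nM, which is a limit and not a number. Compound 3 (`CCOC(=O)c1cc(C#CCCO)c2cc(OC)ccc2n1`) reads > 150000 nM, which is also only a limit, so it has no measured number of its own.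

Among the measured compounds shown here, two measured steps bear on what comes next. Exchanging the selenium-linked aromatic ring for the 4-hydroxybut-1-yn-1-yl chain gave an at least 4.5-fold higher number from compound 1 to compound 3 (0.65 log units; beyond the scatter). Adding methoxy to the selenium-linked ring gave an at least 1.6-fold higher number from compound 1 to compound 2 (0.21 log units; that floor lies within the scatter), so that change has not been shown to exceed the scatter.

Compound 4 (`CCOC(=O)c1cc([Se]c2ccccc2C)c2cc(OC)ccc2n1`) reverses the direction of the larger change: a group of 8 heavy atoms (7 carbon, 1 selenium; one six-membered aromatic ring of carbon only) in place of a group of 5 heavy atoms (4 carbon, 1 oxygen; no ring), on an aromatic carbon. It regains a selenium-linked aromatic ring, so the number is expected to fall back towards that of compound 1, which is 33000 nM. The expected step is an at least 4.1-fold lower number from compound 3 to compound 4 (0.61 log units; beyond the scatter), towards a lower number and beyond the scatter. The estimate for compound 4 is 36000 nM, with an expected range from 15000 nM to 85000 nM.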

Compound 4, half-maximal effective concentration: 38900 nM
Estimate against measurement, compound 4: 1.1-fold (0.03 log units) below; low and high end bracket the measured number.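

In this assay, the 2-methylphenyl group on selenium at the carbon opposite the ring nitrogen gives an at least 3.8-fold lower number from compound 3 to compound 4 (0.58 log units; beyond the scatter), so a second selenium-linked aromatic ring also reads lower than the 4-hydroxybut-1-yn-1-yl chain, while the methyl itself gives a 1.2-fold higher number from compound 1 to compound 4 (0.07 log units; within the scatter), which shows no change from adding it. That first step starts from compound 3, whose reading is a limit and not a number: the limit of > 150000 nM in this assay, at which 1 of the 4 values shown sits.

Exchanging 4-methoxyphenyl for 2-methylphenyl gives an at least 1.3-fold lower number from compound 2 to compound 4 (0.14 log units; that floor lies within the scatter), not shown to exceed the scatter, and compound 2 also holds only a limit: the limit of >= 54300 nM in this assay, at which 1 of the 4 values shown sits.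

Going by these compounds, it remains open how the number responds to a carboxylic acid or an amine on the selenium-linked ring. A methyl at another carbon of that ring, or a longer chain on the selenium, is equally untested among these compounds.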